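The source may hold more compounds than are shown below. What is called first, only, known or untested is meant among the compounds shown, and "the series" means these compounds.

Working notes on the series, all in a functional assay on MOLT-4 cells (Homo sapiens) for inhibition, read by MTT assay, with a stated time of 72 h; on this read-out lower numbers stand for stronger inhibition and higher numbers for weaker inhibition. Compound 1 `COc1cc(NC(C)CCCNC(=O)NNC(=O)Nc2ccc(C(F)(F)F)cc2)c2ncccc2c1` gives 24000 nM, and compound 3 `COc1cc(NC(C)CCCNC(=O)NNC(=O)Nc2cccc(C(F)(F)F)c2)c2ncccc2c1` gives 36000 nM. Compound 2 `COc1cc(NC(C)CCCNC(=O)NNC(=O)Nc2ccc(Br)cc2)c2ncccc2c1` gives 209000 nM, the highest of the three numbers.

Compound 4 `COc1cc(NC(C)CCCNC(=O)Nc2ccc(Cl)cc2)c2ncccc2c1` is unmeasured. It differs from compound 2 as follows: 4-chlorophenyl in place of ((4-bromophenyl)carbamoyl)amino on an amide-type nitrogen. In words, this is 4-chlorophenyl in place of ((4-bromophenyl)carbamoyl)amino on an amide-type nitrogen.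

Among the measured compounds shown here, no measured step makes this change, so the evidence is indirect. The available steps only swap the substituted phenyl group: an 8.7-fold higher number from compound 1 to compound 2 (0.94 log units; beyond the scatter) and a 5.8-fold lower number from compound 2 to compound 3 (0.76 log units; beyond the scatter), both modest, and a 1.5-fold higher number from compound 1 to compound 3 (0.18 log units; within the scatter), which stays within the scatter. Since compound 2 is the high outlier of the three, the working expectation is that compound 4 falls closer to compound 1 and compound 3, as the modest 5.8-fold lower number from compound 2 to compound 3 (0.76 log units; beyond the scatter) suggests. That gives a modest move towards a lower number in this assay, with wide uncertainty.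

The expected step is a 4.2-fold lower number from compound 2 to compound 4 (0.62 log units; beyond the scatter).

For compound 4 the estimate is 50000 nM, with an expected range of 12000 nM to 200000 nM.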

Compound 4, half-maximal inhibitory concentration: 24000 nM
The estimate for compound 4 lay 2.1-fold (0.32 log units) above the measured number, and the stated range covers the measured number.
By their numbers in this assay, from the lowest: compounds 1, 4 and 3 (each within the scatter of the next); then compound 2.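

Among the compounds shown here, at this amide-type nitrogen, 4-chlorophenyl can stand in place of the whole ((4-bromophenyl)carbamoyl)amino group, and in this assay this gives an 8.7-fold lower number from compound 2 to compound 4 (0.94 log units; beyond the scatter) for the change; the earlier steps only swapped the substituted phenyl group. Compound 4 falls within the scatter of compound 1 and compound 3, so among these compounds the ((4-bromophenyl)carbamoyl)amino group is not needed to reach this level of inhibition. Nothing measured on these compounds speaks to the cause of this step.

As far as these compounds go, this one step changes the attachment and the halogen together, so the share of each stays open. Also open, from the compounds shown here alone, is whether an amine, a carboxylic acid or a longer chain in place of the chlorine of compound 4 would hold this level.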